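The source may hold more compounds than are shown below. What is called first, only, known or untested is meant among the compounds shown, and "the series" means these compounds.

Two compounds share a core built around a five-membered aromatic ring with two nitrogens, each carrying a methyl group and a substituted benzyl arm, and differ in what hangs from the ring carbon and in the ether on the benzyl arm. Compound 1 `Cc1cc(C(=O)NCc2ccccn2)nn1Cc1cc(Cl)ccc1OCc1ccccc1` and compound 2 `Cc1cc(C(=O)NN2CCCCC2)nn1Cc1cc(Cl)ccc1OCC(C)C` were both tested in an assay on CHO-K1 cells for displacement of a labelled ligand from prostaglandin E2 receptor EP1 subtype (Homo sapiens); on this read-out higher numbers stand for weaker inhibition and lower numbers for stronger inhibition. In this assay compound 1 gives 25.1 nM, and compound 2 gives 200 nM. Compound 2 thus stands at the higher of the two numbers, the weaker end of what has been measured, and its gap to compound 1 lies beyond the usual scatter; since the two differ in more than one place, no single change can be credited for that gap.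

Compound 3 `Cc1cc(NC(=O)C2CCCCC2)nn1Cc1cc(Cl)ccc1OCC(C)C` keeps the side chain of compound 2 and alters only the group on the ring carbon: (cyclohexylcarbonyl)amino in place of (piperidin-1-yl)carbamoyl on an aromatic carbon. The amide is, in effect, turned around, with the cyclohexane ring replacing the piperidine ring.

Among the compounds with values here, with no measured pair of this kind to lean on, a modest step from compound 2 to compound 3 toward weaker inhibition is expected, a 2.0-fold higher number from compound 2 to compound 3 (0.30 log units; within the scatter), though staying within scatter is also plausible. Compound 3 is estimated at 400 nM, with a range from 100 nM to 1600 nM.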

Compound 3, half-maximal inhibitory concentration: 31.6 nM
For compound 3 the middle estimate is 13-fold (1.10 log units) above the measured one, outside the stated range (below it).
By their numbers in this assay, from the lowest: compounds 1 and 3 (each within the scatter of the next); then compound 2.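

Swapping (piperidin-1-yl)carbamoyl for (cyclohexylcarbonyl)amino on this aromatic carbon gives, in this assay, a 6.3-fold lower number from compound 2 to compound 3 (0.80 log units; beyond the scatter), which shows that the group at this position can shift the number clearly while the ether on the benzyl arm stays the same. The two groups are alike in several plain counts, with 9 heavy atoms, one six-membered non-aromatic ring and 1 hydrogen-bond donor each, yet the amide is turned around, the ring is of carbon only, and there is 1 hydrogen-bond acceptor in place of 2. No measurement here explains the step, so it cannot be tied to any one of these differences.

Going by these compounds, the turned-around amide and the swap of ring are joined in this single step, so their separate shares stay open, and a smaller ring such as cyclopentyl or an open chain such as n-pentyl on the same amide would test how much the cyclohexane ring itself matters. On these data alone, it also stays open whether a step of this size would recur with another ether on the benzyl arm, such as a methoxy group.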